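Amide variation on the 3-chlorophenyl oxadiazole azetidine series

The source may hold more compounds than are shown below. What is called first, only, known or untested is meant among the compounds shown, and "the series" means these compounds.

Measured compounds, all in an assay on HEK293 cells for positive allosteric modulation of metabotropic glutamate receptor 5 (Homo sapiens), read by FLIPR; on this read-out lower numbers stand for an effect already at smaller amounts and higher numbers for an effect only at larger amounts of compound:
compound 1 `O=C(C1CCC(F)(F)CC1)N1CC(c2nc(-c3cccc(Cl)c3)no2)C1`: 180 nM
compound 2 `O=C(N1CCCCCC1)N1CC(c2nc(-c3cccc(Cl)c3)no2)C1`: 47 nM
compound 3 `O=C(C1CCCO1)N1CC(c2nc(-c3cccc(Cl)c3)no2)C1`: a limit of the assay, > 10000 nM

Of the two numbers, compound 1 carries the higher one; its nearest neighbour is compound 2, and a 3.8-fold lower number from compound 1 to compound 2 (0.58 log units; beyond the scatter). The value of compound 3 is only a limit, the one noted as the limit of > 10000 nM in this assay, at which 1 of the 3 values shown sits. Against that limit, an at least 55-fold higher number from compound 1 to compound 3 (1.74 log units; beyond the scatter) and an at least 210-fold higher number from compound 2 to compound 3 (2.32 log units; beyond the scatter). All three measured steps change the group on the carbonyl carbon and leave the aryl ring untouched.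

Compound 4 `Cc1cccc(-c2noc(C3CN(C(=O)C4CCC(F)(F)CC4)C3)n2)c1` differs from compound 1 by methyl in place of chloro on an aromatic carbon. Going by the values given here, no measured step touches this aromatic position, so none of them bears on it; the measured steps show only that the carbonyl side moves the read-out strongly. With no comparable change to go on, compound 4 is expected to stay close to compound 1, with a 1.4-fold higher number from compound 1 to compound 4 (0.14 log units; within the scatter) as the expected step, inside or near the scatter. Compound 4 is estimated at 250 nM, with a range from 80 nM to 800 nM.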

Compound 4, half-maximal effective concentration: 590 nM
Beside the measured number, compound 4's estimate is 2.4-fold (0.37 log units) below it, within the range that was stated.
By their numbers in this assay, from the lowest: compound 2; then compound 1; then compound 4. At a limit, above all of these: compound 3.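

In this assay the aromatic position, meta to a large group, also moves the read-out: methyl in place of chloro gives a 3.3-fold higher number from compound 1 to compound 4 (0.52 log units; beyond the scatter). Until now only the carbonyl side had been seen to matter, whereas this result shows that the 3-chlorophenyl to 3-methylphenyl change alone, with the 4,4-difluorocyclohexyl amide held constant, carries a modest step beyond the scatter. Nothing measured here gives a cause for this step.

Open, on these data alone, is whether the same change reads alike with azepan-1-yl on the carbonyl carbon, since a single pair rests on one amide only. Also open, as far as these compounds go, is how fluoro, methoxy, nitrile or trifluoromethyl would read on this aromatic carbon in place of chloro.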